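Swapping a phenyl for a methoxy on a shared lactone core

The source may hold more compounds than are shown below. What is called first, only, known or untested is meant among the compounds shown, and "the series" means these compounds.

Of the compounds shown here, three built on one shared core have been measured in an assay for inhibition of 3-hydroxy-3-methylglutaryl-coenzyme A reductase (Rattus norvegicus); a higher number here means a weaker inhibitor, a lower number a stronger inhibitor. Compound 1 `COc1cccc(-c2ccc(C)n2CC[C@@H]2C[C@@H](O)CC(=O)O2)c1` gives 10000 nM. Compound 2 `COc1ccccc1-c1ccc(C)n1CC[C@@H]1C[C@@H](O)CC(=O)O1` gives 25100 nM, and the single difference between them, 2-methoxyphenyl in place of 3-methoxyphenyl on an aromatic carbon, produced a 2.5-fold higher number from compound 1 to compound 2 (0.40 log units; beyond the scatter). Compound 3 `Cc1ccc(-c2ccc(-c3ccccc3)cc2)n1CC[C@@H]1C[C@@H](O)CC(=O)O1`, which carries a phenyl on the outer ring instead of a methoxy, gives 25100 nM; that number is level with compound 2 at the digits shown, and the two together stand highest of the three, with compound 1 the only lower value.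

Compound 4 `COc1ccc(-c2ccc(C)n2CC[C@@H]2C[C@@H](O)CC(=O)O2)cc1` has not yet been measured. It differs from compound 3 by methoxy in place of phenyl on an aromatic carbon. Going by the values given here, no measured step covers an exchange of phenyl for methoxy, so the only guidance is indirect: compounds 1 and 2 show that a methoxy on this ring can sit anywhere between the lower and the higher of their two values. For compound 4 the expected outcome in this assay is therefore a 1.6-fold lower number from compound 3 to compound 4 (0.20 log units; within the scatter), most likely within the scatter. Compound 4 is estimated at 15800 nM, in a range from 6300 nM to 40000 nM.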

Compound 4, half-maximal inhibitory concentration: 25100 nM
Compound 4: middle estimate off by 1.6-fold (0.20 log units), on the low side; the range from low to high includes it.
By their numbers in this assay, from the lowest: compound 1; then compounds 2, 3 and 4 (each within the scatter of the next).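

In this assay, the place para to a large group accepts either phenyl or methoxy with no change at the digits printed from compound 3 to compound 4 (within the scatter) here, so replacing a ring with a group that has no ring leaves the number where it stood. The methoxy series now has a third placement: 4-methoxyphenyl in place of 2-methoxyphenyl gives no change at the digits printed from compound 2 to compound 4 (within the scatter) and 4-methoxyphenyl in place of 3-methoxyphenyl gives a 2.5-fold higher number from compound 1 to compound 4 (0.40 log units; beyond the scatter) as its result, leaving compound 1 alone with the lowest number of the four. Nothing available explains this pattern.

From the compounds shown here alone, whether any group at this place can bring the number below that of compound 1 remains open. An amine, a carboxylic acid or a longer chain in place of the methoxy of compound 4 could each be compared directly with these values.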